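From 3-methylthiophen-2-yl to 3-bromofuran-2-yl on the shared core

The compounds below may be only part of what the source reports. "The series", "measured", "known", "first", "only" and "open" are said of these compounds alone.

Among the measured compounds shown here, in a functional assay on MCF7 cells (Homo sapiens) for cytotoxicity, read by MTT assay (on this read-out higher numbers stand for weaker inhibition and lower numbers for stronger inhibition), compound 1 (`COc1ccc(OC)c(C(=O)/C=C/c2ccsc2)c1`) gives 3700 nM and compound 2 (`COc1ccc(OC)c(C(=O)/C=C/c2sccc2C)c1`) gives 7600 nM, so compound 2 holds the higher of the two numbers so far. Compound 3 (`COc1ccc(OC)c(C(=O)/C=C/c2occc2Br)c1`) carries 3-bromofuran-2-yl in place of 3-methylthiophen-2-yl on a double-bonded chain carbon bound to a double-bonded chain carbon. For the measured compounds named here, one measured step bears on this change: a 2.1-fold higher number from compound 1 to compound 2 (0.31 log units; beyond the scatter), a modest exchange at the same place, with thiophen-3-yl leaving and 3-methylthiophen-2-yl entering. Going by the values given here, no measured compound carries 3-bromofuran-2-yl, so the size of a step to it stays poorly defined. A step of similar or smaller size is therefore expected in this assay, and the direction is only a weak guess. The expected step is a 1.5-fold lower number from compound 2 to compound 3 (0.18 log units; within the scatter), which would not clearly leave the scatter. For compound 3 the estimated value is 5000 nM, with an expected range of 1800 nM to 14000 nM.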

Compound 3, half-maximal inhibitory concentration: 11000 nM
For compound 3 the middle estimate is 2.2-fold (0.34 log units) below the measured one; the range from low to high includes it.
By their numbers in this assay, from the lowest: compound 1; then compounds 2 and 3 (each within the scatter of the next).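

In this assay, 3-bromofuran-2-yl in place of 3-methylthiophen-2-yl gives a 1.4-fold higher number from compound 2 to compound 3 (0.16 log units; within the scatter), so on a double-bonded chain carbon bound to a double-bonded chain carbon these two groups are not told apart, even though they differ in ring hetero atom and in the group carried on the ring. Against thiophen-3-yl, the same exchange gives a 3.0-fold higher number from compound 1 to compound 3 (0.47 log units; beyond the scatter), so both groups that carry a ring substituent read higher than the unsubstituted ring of compound 1 in this set of three. Nothing on hand accounts for either step.

The three compounds do not separate the roles of ring substituent, ring hetero atom and point of attachment. Unsubstituted thiophen-2-yl and furan-2-yl would bear on that question, while phenyl and pyridin-3-yl at this place lie outside what is shown.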